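A Second Methoxy on the Aryl Ring of Compound 1

The source may report more compounds than this note shows. Statements on the series, on what has been measured and on what is new or still open speak of the compounds shown alone.

Of the compounds shown here, three sharing one core have been measured in a functional assay on MCF7 cells (Homo sapiens) for cytotoxicity, read by sulforhodamine B assay, with a stated time of 48 h; a lower number here means a stronger inhibitor of growth, a higher number a weaker inhibitor of growth. Compound 1 `COc1ccc(/C(Cl)=C/C=C(\C#N)C(=O)c2c[nH]c3ccccc23)cc1` gives 47300 nM, which is the lowest of the two numbers obtained. Compound 2 `Cc1[nH]c2ccccc2c1C(=O)/C(C#N)=C/C=C(\Cl)c1ccc(Br)cc1` gives 73900 nM, a number that sits within the scatter of compound 1, so the two cannot be ordered. Compound 3 `N#C/C(=C\C=C(/Cl)c1ccc(Br)cc1)C(=O)c1c[nH]c2ccc(Br)cc12` reaches only the limit of the assay, > 100000 nM, and no number is known for it; this is the limit of > 100000 nM in this assay, at which 1 of the 3 values shown sits.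

Compound 4 `COc1ccc(/C(Cl)=C/C=C(\C#N)C(=O)c2c[nH]c3ccccc23)cc1OC` has not yet been measured. It differs from compound 1 in one place: methoxy in place of hydrogen on an aromatic carbon. The added methoxy sits ortho to a methoxy group and meta to a large group. Among the compounds with values here, no pair of measured compounds differing in one place is available, so the step cannot be read from a measured precedent.

Given that every measured value lies at or near the weak end of this assay, the step is expected to be small, in either direction or none beyond the scatter. Compound 4 is therefore estimated to give 40000 nM, expected between 15000 nM and 120000 nM, meaning an expected step of a 1.2-fold lower number from compound 1 to compound 4 (0.07 log units; within the scatter).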

Compound 4, concentration for 50% growth inhibition: 44200 nM
Compound 4: the middle estimate sits 1.1-fold (0.04 log units) below what was measured; measured number inside the range.
By their numbers in this assay, from the lowest: compounds 4, 1 and 2 (each within the scatter of the next). At a limit, above all of these: compound 3.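

Within the data shown here, this is the first step on the shared core that can be read from two measured compounds. In this assay, methoxy in place of hydrogen on an aromatic carbon, ortho to a methoxy group and meta to a large group, gives a 1.1-fold lower number from compound 1 to compound 4 (0.03 log units; within the scatter), so at this position the added methoxy leaves the reading within the scatter and compound 4 still returns a true number. Compound 3 remains the only compound at a limit, which is not a number: the limit of > 100000 nM in this assay, at which 1 of the 4 values shown sits.

On these data alone, whether another group at this position, such as an amine, a carboxylic acid or a longer chain, would also stay within the scatter remains open. The compounds shown also leave open whether the same methoxy step would hold on the other compounds sharing this core.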